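Swapping trifluoromethyl for methylsulfanyl on a chalcone boron series

A few compounds are considered here, and "the series" means these few. Any claim that something is new, unique, unknown or untested is made for them only; others in the source may bear on it.

Of the compounds shown here, three of one family have been tested so far in an ADME assay on L929 cells (Mus musculus) for cytotoxicity, read by resazurin assay, with a stated time of 72 h; a lower number here means a stronger inhibitor, a higher number a weaker inhibitor. Compound 1, `O=C(/C=C/c1ccc2c(c1)B(O)OC2)c1ccc(Cl)c(Cl)c1`, gives only a limit of the assay in this assay, > 10 ug/mL. Compound 2, `O=C(/C=C/c1ccc2c(c1)B(O)OC2)c1ccc(C(F)(F)F)cc1`, likewise gives a limit rather than a number in this assay, > 10 ug/mL. Compound 3, `O=C(/C=C/c1ccc2c(c1)B(O)OC2)c1ccccc1O`, also gives a limit in this assay, > 10 ug/mL. So compound 2 stands exactly where the other two stand: at the limit, with no number to rank it, as the evidence summarises (the limit of > 10 ug/mL in this assay, at which 3 of the 3 values shown sit).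

Compound 4, `CSc1ccc(C(=O)/C=C/c2ccc3c(c2)B(O)OC3)cc1`, is the next to be measured. It differs from compound 2 in one place: methylsulfanyl in place of trifluoromethyl on an aromatic carbon.

Going by the values given here, no step between two measured compounds is available, so there is nothing to set a scale for this change. Given that every value so far sits at the limit, the step is expected to be small or none beyond the scatter, a step that the limit leaves unreadable from compound 2 to compound 4. For compound 4 the estimate in this assay is 20 ug/mL, within a range from 8 ug/mL to 60 ug/mL, with a good chance that only a limit is reported again.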

Compound 4, half-maximal inhibitory concentration: > 10 ug/mL
Compound 4: only a limit was reported (the forecaster's own chance of this, stated with the estimate: 80%); the middle value does not contradict the limit.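

Going by these compounds alone, compound 4 gives only a limit in this assay, > 10 ug/mL, just as compound 2 does, so no step between these two compounds can be read. The compounds shown leave open what actual number any of them would give, and whether methylsulfanyl and trifluoromethyl differ at all here.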